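Fluoro in place of bromo: working notes

A few compounds are considered here, and "the series" means these few. Any claim that something is new, unique, unknown or untested is made for them only; others in the source may bear on it.

- compound 1 `O=C1O/C(=C\Cn2cc(I)c(=O)[nH]c2=O)C(OCc2ccccc2)=C1OCc1ccccc1`: 7500 nM
- compound 2 `O=C1O/C(=C\Cn2ccc(=O)[nH]c2=O)C(OCc2ccccc2)=C1OCc1ccccc1`: 12900 nM
- compound 3 `O=C1O/C(=C\Cn2cc(Br)c(=O)[nH]c2=O)C(OCc2ccccc2)=C1OCc1ccccc1`: 7500 nM

In a functional assay on L1210 cells (Mus musculus) for inhibition (a higher number here means a weaker inhibitor, a lower number a stronger inhibitor), compound 3 reads the same as compound 1, and all three values lie within the scatter of one another. The next structure is compound 4 `O=C1O/C(=C\Cn2cc(F)c(=O)[nH]c2=O)C(OCc2ccccc2)=C1OCc1ccccc1`, reached from compound 3 by fluoro in place of bromo on an aromatic carbon. Three measured steps at this place bear on it: no change at the digits printed from compound 1 to compound 3 (within the scatter), a 1.7-fold lower number from compound 2 to compound 3 (0.24 log units; within the scatter) and a 1.7-fold higher number from compound 1 to compound 2 (0.24 log units; within the scatter). Among the measured compounds shown here, none of them exceeds the scatter, although no fluoro compound has been measured yet. No step beyond the scatter is therefore expected in this assay, and the expected step is a 1.1-fold lower number from compound 3 to compound 4 (0.03 log units; within the scatter). The estimated value for compound 4 is 7000 nM, with an expected range of 1500 nM to 14000 nM.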

Compound 4, half-maximal inhibitory concentration: 5100 nM
Compound 4: middle estimate off by 1.4-fold (0.14 log units), on the high side; low and high end bracket the measured number.
By their numbers in this assay, from the lowest: compounds 4, 1, 3 and 2 (each within the scatter of the next, the first and the last beyond it).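

In this assay, among the compounds shown here, fluoro is the first group at this position to separate from hydrogen beyond the scatter, though only modestly (a 2.5-fold lower number from compound 2 to compound 4 (0.40 log units; beyond the scatter)). It does not separate from the other halogens (a 1.5-fold lower number from compound 3 to compound 4 (0.17 log units; within the scatter); a 1.5-fold lower number from compound 1 to compound 4 (0.17 log units; within the scatter)), so no order among fluoro, bromo and iodo can be read. No measured evidence bears on the origin of these small steps.

Open, on these data alone, is whether a methyl, an amine or a nitrile at this position would give a larger step. Also open, as far as these compounds go, is whether the fluoro gain carries over to changes in the two benzyl ether groups.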